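Trading Phenoxy for Chloro in a Muscarinic Modulator Series

The source may hold more compounds than are shown below. What is called first, only, known or untested is meant among the compounds shown, and "the series" means these compounds.

Compound 1 `O=C1C(=O)N(CCOc2ccc(Oc3ccccc3)cc2)c2ccc(OC(F)(F)F)cc21` stands highest of the two compounds measured in an assay on isolated protein for positive allosteric modulation of muscarinic acetylcholine receptor M5 (Homo sapiens) (a higher number here means a larger maximal response, a lower number a smaller maximal response), where compound 1 gives 93%. Compound 2 `COc1ccc(CN2C(=O)C(O)(c3ccc(F)nc3)c3cc(OC(F)(F)F)ccc32)cc1` gives 74%, a gap that lies beyond the usual scatter. Compound 3 `O=C1C(=O)N(CCOc2ccc(Cl)cc2)c2ccc(OC(F)(F)F)cc21` differs from compound 1 by a single change: chloro in place of phenoxy on an aromatic carbon, the entering group sitting para to a large group. For the measured compounds named here, no step between measured compounds covers this change, so its size is uncertain. The step expected here is a modest decrease, a number 13 percentage points lower from compound 1 to compound 3 (beyond the scatter). Compound 3 is therefore estimated to reach 80%, within a range from 55% to 105%.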

Compound 3, largest response reached (Emax), in percent of the reference or control that the assay uses: 92%
Estimate against measurement, compound 3: 12 percentage points below, within the range that was stated.
By their numbers in this assay, from the lowest: compound 2; then compounds 3 and 1 (each within the scatter of the next).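

Placing chloro in place of phenoxy on this aromatic carbon, para to a large group, gives a number 1 percentage points lower from compound 1 to compound 3 (within the scatter) in this assay. At this position, then, the maximal response does not depend on the six-membered aromatic ring that phenoxy carries, and the single chlorine atom serves as well in this assay. No available measurement gives a reason for this. On these data alone, it remains open whether a fluoro, an amine or a carboxylic acid on the same carbon would hold the response in the same way.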